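A few compounds are considered here, and "the series" means these few. Any claim that something is new, unique, unknown or untested is made for them only; others in the source may bear on it.

The measured compounds:
compound 1 `O=C1CC(c2nc(-c3ccc(F)cc3)no2)CN1c1ccc(Cl)cc1` gives 1700 nM in an in vitro functional assay on HEK293-A cells for positive allosteric modulation of metabotropic glutamate receptor 5 (Homo sapiens), read by FLIPR and calcium flux; a lower number here means that less compound is needed, a higher number that more compound is needed for the effect;
compound 2 `O=C1CC(c2nc(-c3ccc(Cl)cc3)no2)CN1c1ccc(Cl)c(Cl)c1` gives 1100 nM;
compound 3 `O=C1CC(c2nc(-c3cccc(F)c3)no2)CN1c1ccc(F)cc1` gives 88 nM.

Among these three numbers in this assay, compound 2 stands second highest. Its nearest neighbour is compound 1, whose number is higher by a margin within the scatter; compound 3 lies far below it, beyond the scatter. Compound 4 `O=C1CC(c2nc(-c3ccc(F)cc3)no2)CN1c1ccc(Cl)c(Cl)c1` is not yet measured and differs from compound 2 in one place: fluoro in place of chloro on an aromatic carbon. Going by the values given here, no measured pair differs by this change alone, so there is no direct step to go by. A small step in this assay is expected, in no certain direction, and probably none beyond the scatter. The expected step is a 1.2-fold higher number from compound 2 to compound 4 (0.07 log units; within the scatter). Compound 4 is thus estimated at 1300 nM, within 500 nM to 3500 nM.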

Compound 4, half-maximal effective concentration: 2300 nM
Beside the measured number, compound 4's estimate is 1.8-fold (0.25 log units) below it, within the range that was stated.
By their numbers in this assay, from the lowest: compound 3; then compounds 2, 1 and 4 (each within the scatter of the next, the first and the last beyond it).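

In this assay, going by these compounds alone, the exchange of 4-chlorophenyl for 4-fluorophenyl gives a 2.1-fold higher number from compound 2 to compound 4 (0.32 log units; beyond the scatter) and so offers the first direct reading of this change, a modest one at this place para to a large group. Chloro in place of hydrogen on an aromatic carbon gives a 1.4-fold higher number from compound 1 to compound 4 (0.13 log units; within the scatter) and so does not stand out from the usual scatter. Nothing at hand explains either step.

Going by these compounds, whether the fluoro-for-chloro step holds with the rest of the molecule altered remains open. Also open, on these data alone, is how a methoxy group, a nitrile or an amine would fare at this place.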